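Removing a large group from compound 1

The compounds below may be only part of what the source reports. "The series", "measured", "known", "first", "only" and "open" are said of these compounds alone.

In a functional assay on KB cells (Homo sapiens) for antiproliferative activity, read by sulforhodamine B assay, with a stated time of 48 h (on this read-out lower numbers stand for stronger inhibition of growth and higher numbers for weaker inhibition of growth), compound 1 (`COc1ccc(S(=O)(=O)Nc2cccc(CCc3ccc(C(=O)Nc4ccccc4N)cc3)c2)cc1`) gives 678 nM. Going by the values given here, this is the lower of the two numbers known so far and lies beyond the usual scatter from the second measured molecule, compound 2 (`COc1ccc(S(=O)(=O)Nc2ccccc2CCc2ccccc2)cc1`), which gives 4410 nM.

The next molecule, compound 3 (`Nc1ccccc1NC(=O)c1ccc(CCc2ccccc2)cc1`), is a cut-down form of compound 1: hydrogen in place of ((4-methoxyphenyl)sulfonyl)amino on an aromatic carbon. In words, this is hydrogen in place of ((4-methoxyphenyl)sulfonyl)amino on an aromatic carbon, meta to a large group. Among the compounds with values here, no measured pair shows this change alone, so any forecast is uncertain. Within the data shown here, the only guide is that compound 1 gives 678 nM with the group present. An upward step toward weaker growth inhibition is expected, with an estimated size of a 4.4-fold higher number from compound 1 to compound 3 (0.65 log units; beyond the scatter). For compound 3, the estimate is 3000 nM, with an expected range from 900 nM to 12000 nM.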

Compound 3, concentration for 50% growth inhibition: > 10000 nM
Compound 3: a limit, no number (the forecaster's own chance of this, stated with the estimate: 15%); middle value at least 3.3-fold (0.52 log units) from the limit.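

Going by these compounds alone, compound 1 and compound 3 form the first pair that differs in one place, so the contribution of this group can now be read directly. Replacing ((4-methoxyphenyl)sulfonyl)amino with hydrogen on this aromatic carbon gives an at least 14-fold higher number from compound 1 to compound 3 (1.16 log units; beyond the scatter), which shows that growth inhibition in compound 1 depends strongly on having the group at this place. In this assay compound 3 gives > 10000 nM, which is a limit and not a number, so the full size of the step cannot be read: the limit of > 10000 nM in this assay, at which 1 of the 3 values shown sits.

The compounds shown do not reveal which part of the group matters, such as whether a simple amine here, keeping only the nitrogen, would retain any growth inhibition. They also leave open whether a methylsulfonylamino group, which lacks the 4-methoxyphenyl ring, would be enough.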